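Urea to Benzamide: What Compound 4 Should Show

The source may hold more compounds than are shown below. What is called first, only, known or untested is meant among the compounds shown, and "the series" means these compounds.

Compound 1, `COc1cc(-c2nn(-c3cccc(NC(=O)c4cccc(C(F)(F)F)c4)c3)cc2-c2ccncc2)ccc1Cl`, gives in a functional assay on CAKI-1 cells (Homo sapiens) for inhibition, read by sulforhodamine B assay, with a stated time of 48 h (a higher number here means a weaker inhibitor of growth, a lower number a stronger inhibitor of growth), only a limit, > 50000 nM.
Compound 2, `COc1cc(-c2nn(-c3cccc(NC(=O)c4ccc(Cl)c(C(F)(F)F)c4)c3)cc2-c2ccncc2)ccc1Cl`, gives in this assay only a limit, > 32500 nM.
Compound 3, `COc1cc(-c2nn(-c3cccc(NC(=O)Nc4ccc(Cl)c(C(F)(F)F)c4)c3)cc2-c2ccncc2)ccc1Cl`, gives in this assay 4720 nM.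

Going by the values given here, compound 3 therefore stands as the only real number among the three values; the other two are limits of the assay (the limit of > 32500 nM in this assay, at which 1 of the 3 values shown sits, and (the limit of > 50000 nM in this assay, at which 1 of the 3 values shown sits)). Compound 4, `COc1cc(-c2nn(-c3cccc(NC(=O)c4ccccc4)c3)cc2-c2ccncc2)ccc1Cl`, has not yet been measured. It differs from compound 3 by phenyl in place of (4-chloro-3-(trifluoromethyl)phenyl)amino on a carbonyl carbon, so the urea of compound 3 becomes a plain benzamide.

Among the compounds with values here, two measured steps bear on this change, both running in the opposite direction: an at least 10-fold lower number from compound 1 to compound 3 (1.02 log units; beyond the scatter), and an at least 6.8-fold lower number from compound 2 to compound 3 (0.83 log units; beyond the scatter). In each, the move from an amide to the urea of compound 3 brought a clear drop in the number. Compound 4 reverses that move and also gives up the chloro and trifluoromethyl groups; the step from compound 1 to compound 2 is unreadable on that point (a step that the two limits leave unreadable from compound 1 to compound 2).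

A large rise, beyond the scatter, is therefore expected, quite possibly ending at a limit. Compound 4 is expected near 50000 nM, within 15000 nM to 150000 nM. The expected step is an 11-fold higher number from compound 3 to compound 4 (1.03 log units; beyond the scatter).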

Compound 4, concentration for total growth inhibition: > 100000 nM
Compound 4 gave a limit, no number; the forecaster's own chance of this, stated with the estimate: 70%; at least 2.0-fold (0.30 log units) between middle value and limit.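

In this assay compound 4 also yields no number, only a limit of the assay: the limit of > 100000 nM in this assay, at which 1 of the 4 values shown sits.

Even so, the result gives an at least 21-fold higher number from compound 3 to compound 4 (1.32 log units; beyond the scatter), which shows that on this carbonyl carbon, phenyl does not retain the measurable growth inhibition seen with (4-chloro-3-(trifluoromethyl)phenyl)amino. Going by these compounds alone, compound 1, compound 2 and compound 4 now all stand at limits, and the steps from compound 1 and compound 2 to compound 4 cannot be read, so the plain benzamide adds a third amide without a number, no order can be given among the three, and compound 3 remains the only urea and the only compound with a real value.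

Because this change removes the amide-type nitrogen link and the chloro and trifluoromethyl groups together, the compounds shown leave open which of these parts carries the difference. A urea with plain phenylamino on the carbonyl carbon, or a carbamate with phenoxy there, would begin to separate the linking nitrogen from the ring substituents.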